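The compounds below may be only part of what the source reports. "The series", "measured", "known", "first", "only" and "open" are said of these compounds alone.

Measured compounds:

Compound 1, `CCOC(=O)N1CCC(=NNC(=O)c2ccc(Cl)cc2)CC1`, gives 59000 nM in a functional assay, read by spectrophotometry, with a stated time of 2 h; a higher number here means a weaker inhibitor, a lower number a stronger inhibitor.
Compound 2, `CCOC(=O)N1CCC(=NNC(=O)c2ccc(F)cc2)CC1`, gives 74800 nM in this assay.
Compound 3, `O=C(NN=C1CC(c2ccccc2)NC(c2ccccc2)C1)c1ccc(Cl)cc1`, gives 96700 nM in this assay.

All three numbers sit close together, and none of the gaps between them reaches beyond the usual scatter of repeated runs, so no ordering of the three is claimed. Going by the values given here, the one change seen twice in this set is fluoro in place of chloro on an aromatic carbon. Between compound 1 and compound 2 it gave a 1.3-fold higher number from compound 1 to compound 2 (0.10 log units; within the scatter).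

Compound 3 carries a core that is not the same as that of compound 1; the difference between the two cores is not broken down here. The unmeasured compound 4, `O=C(NN=C1CC(c2ccccc2)NC(c2ccccc2)C1)c1ccc(F)cc1`, is related to compound 3 by fluoro in place of chloro on an aromatic carbon. The place of the change is described in the same words for both pairs, so this is taken as the same kind of change applied to a different core.

Among the compounds with values here, with only one earlier instance to go on, and that one within the scatter, a step of similar size is expected from compound 3 to compound 4: a 1.2-fold higher number from compound 3 to compound 4 (0.09 log units; within the scatter) is the estimate, resting on compound 3 at 96700 nM and on the earlier step of a 1.3-fold higher number from compound 1 to compound 2 (0.10 log units; within the scatter). Compound 4 is therefore estimated at 120000 nM in this assay, with a plausible span from 55000 nM to 260000 nM.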

Compound 4, half-maximal inhibitory concentration: 66000 nM
Compound 4: middle estimate off by 1.8-fold (0.26 log units), on the high side, and the stated range covers the measured number.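

In this assay, going by these compounds alone, fluoro in place of chloro on the core of compound 3 gave a 1.5-fold lower number from compound 3 to compound 4 (0.17 log units; within the scatter), so on this core, as on the core of compound 1, the change produced no step that stands out from the scatter. Set beside each other, the two steps give no sign that the core matters: the same change on two cores in this assay, a 1.3-fold higher number (0.10 log units; within the scatter) from compound 1 to compound 2 and a 1.5-fold lower number (0.17 log units; within the scatter) from compound 3 to compound 4, 1.9-fold (0.27 log units) apart, within the scatter of two such steps. Within the data shown here, this shows only that the swap of chloro for fluoro stayed within the scatter on both cores; it does not show that the two cores respond alike, as steps this small could hide a modest influence of the core, and two pairs do not make a rule for the series.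

The compounds shown leave open how either core would answer a group other than these two halogens at the same place, such as a methoxy group, an amine or a carboxylic acid, and whether a larger step, if one appeared, would carry from one core to the other. They also leave open what a second group on that aromatic ring, or a longer chain in place of the ring, would do in this assay.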